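This account rests on a few compounds, and the source may have more. Where it says the series, first, only, none or still open, it means among the compounds named here.

Compounds measured in an assay on CHO cells for displacement of a labelled ligand from prostaglandin D2 receptor 2 (Homo sapiens), read by scintillation counting; a lower number here means a stronger inhibitor, a higher number a weaker inhibitor:

compound 1, `Cc1ccc(S(=O)(=O)Cc2ccccc2)cc1C#Cc1cc(Cl)ccc1OCC(=O)O`: 5 nM
compound 2, `CCS(=O)(=O)c1ccc(C)c(C#Cc2cc(Cl)ccc2OCC(=O)O)c1`: 8.6 nM
compound 3, `Cc1ccc(S(=O)(=O)N(C)C(C)C)cc1C#Cc1cc(Cl)ccc1OCC(=O)O`: 3.8 nM

Compound 3 gives the lowest number of the three in this assay. Its distance to compound 1 is within the scatter, a 1.3-fold lower number from compound 1 to compound 3 (0.12 log units; within the scatter); its distance to compound 2 is modest but beyond the scatter, a 2.3-fold lower number from compound 2 to compound 3 (0.35 log units; beyond the scatter). The step from compound 1 to compound 2, a 1.7-fold higher number from compound 1 to compound 2 (0.24 log units; within the scatter), is also within the scatter. All three compounds share the same core and differ only in the group on the sulfonyl sulfur, and across benzyl, ethyl and isopropyl(methyl)amino that group moves the number little.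

Compound 4, `COCCNS(=O)(=O)c1ccc(C)c(C#Cc2cc(Cl)ccc2OCC(=O)O)c1`, is not yet measured. It differs from compound 3 in one place: (2-methoxyethyl)amino in place of isopropyl(methyl)amino on a sulfonyl sulfur. Both groups are of the same size, but the entering one carries a hydrogen-bond donor and an acceptor where the leaving one has none. Among the compounds with values here, no measured step tests such a group on the sulfonyl sulfur; the steps that do exist on this position are all small, so the expected step from compound 3 to compound 4 in this assay is a 1.6-fold higher number from compound 3 to compound 4 (0.20 log units; within the scatter), at most modest and more likely a slightly higher number. Compound 4 is therefore estimated at 6 nM, with a range from 2.5 nM to 15 nM.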

Compound 4, inhibition constant: 3.6 nM
The estimate for compound 4 lay 1.7-fold (0.22 log units) above the measured number; the range from low to high includes it.
By their numbers in this assay, from the lowest: compounds 4, 3, 1 and 2 (each within the scatter of the next, the first and the last beyond it).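

In this assay, the step of a 1.1-fold lower number from compound 3 to compound 4 (0.02 log units; within the scatter) shows that this position on the sulfonyl sulfur accepts (2-methoxyethyl)amino, with its hydrogen-bond donor and acceptor, in place of isopropyl(methyl)amino without a change that can be told from the scatter. The earlier compounds shown here had tested only groups without either feature here, so the flat picture now extends to a group of the same heavy-atom count with a different make-up. The step of a 2.4-fold lower number from compound 2 to compound 4 (0.38 log units; beyond the scatter) sits alongside a 2.3-fold lower number from compound 2 to compound 3 (0.35 log units; beyond the scatter) and places both amino groups modestly apart from ethyl, while the step of a 1.4-fold lower number from compound 1 to compound 4 (0.14 log units; within the scatter) leaves compound 4 unresolved from the benzyl group of compound 1, and no evidence is available to account for any of these results.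

The compounds shown leave open whether the hydrogen on the sulfonamide nitrogen or the ether oxygen matters on its own, which (2-methoxyethyl)(methyl)amino and propylamino would separate. They also leave open how far the position stays this flat with a charged group such as a dimethylamino-bearing chain or a carboxylic acid, or with a longer chain such as (3-methoxypropyl)amino.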